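Swapping a fluorinated phenyl for a pyridine on the amide

The source may hold more compounds than are shown below. What is called first, only, known or untested is meant among the compounds shown, and "the series" means these compounds.

In an assay on cytosol from placenta for inhibition of 17-beta-hydroxysteroid dehydrogenase type 1 (Homo sapiens), read by HPLC, with a stated time of 10 min, in the presence of a further agent that is not named here (a higher number here means a weaker inhibitor, a lower number a stronger inhibitor), compound 2 `Cc1cc(F)ccc1N(C)C(=O)c1ccc(-c2ccc(O)cc2)o1` gives 23 nM, the lowest of the three numbers measured. Compound 3 `Cc1c(F)cccc1N(C)C(=O)c1ccc(-c2ccc(O)cc2)o1` gives 170 nM, and compound 1 `Cc1ccccc1N(C)C(=O)c1ccc(-c2ccccc2O)o1` gives 1900 nM. Compound 4 `Cc1ncccc1N(C)C(=O)c1ccc(-c2ccc(O)cc2)o1` carries 2-methylpyridin-3-yl in place of 4-fluoro-2-methylphenyl on an amide-type nitrogen. Within the data shown here, no measured pair makes this exact change, so the only step that bears on it is the one at the same position, a 7.4-fold higher number from compound 2 to compound 3 (0.87 log units; beyond the scatter), which shows that reshaping the ring on the amide-type nitrogen can move the number well beyond the scatter. Replacing a carbon ring by one holding a nitrogen is a larger departure than that, so a weakening step is expected, roughly a 5.2-fold higher number from compound 2 to compound 4 (0.72 log units; beyond the scatter). Compound 4 is therefore estimated to give 120 nM, within a range from 30 nM to 500 nM.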

Compound 4, half-maximal inhibitory concentration: 160 nM
The estimate for compound 4 lay 1.3-fold (0.12 log units) below the measured number; measured number inside the range.
By their numbers in this assay, from the lowest: compound 2; then compounds 4 and 3 (each within the scatter of the next); then compound 1.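

On the amide-type nitrogen, 2-methylpyridin-3-yl does not match 4-fluoro-2-methylphenyl (a 7.0-fold higher number from compound 2 to compound 4 (0.84 log units; beyond the scatter)). Set against 3-fluoro-2-methylphenyl, it makes no real difference (a 1.1-fold lower number from compound 3 to compound 4 (0.03 log units; within the scatter)), so among these three groups only 4-fluoro-2-methylphenyl stands apart. Nothing shown here explains why these rings behave this way. Still open, going by these compounds, is whether a pyridine ring that also carries a fluorine would behave like compound 2 or like compound 4. Also open, on these data alone, is how a ring carrying an amine or a methoxy group would fare at this position.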